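Shortening the Chain: Octyl to Hexyl on the Shared Core

This account rests on a few compounds, and the source may have more. Where it says the series, first, only, none or still open, it means among the compounds named here.

Compound 1 `CCCCCN(Cc1ccc(C(=O)NO)cc1)c1ncc(-c2ccc(C)cc2)s1`: 9140 nM
Compound 2 `CCCCCCCCN(Cc1ccc(C(=O)NO)cc1)c1ncc(-c2ccc(C)cc2)s1`: 4630 nM

Of the compounds shown here, two have been measured. In a functional assay on A549 cells (Homo sapiens) for antiproliferative activity, read by MTT assay, with a stated time of 48 h (a lower number here means a stronger inhibitor of growth, a higher number a weaker inhibitor of growth), compound 1 gives 9140 nM, and compound 2 gives 4630 nM. Compound 2 holds the lowest of the two numbers shown, and its only neighbour, compound 1, sits a 2.0-fold lower number from compound 1 to compound 2 (0.30 log units; within the scatter), so the two are not separated beyond the scatter.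

Compound 3 `CCCCCCN(Cc1ccc(C(=O)NO)cc1)c1ncc(-c2ccc(C)cc2)s1` is the next member: hydrogen in place of ethyl on a saturated chain carbon, six bonds along the chain from a nitrogen on an aromatic ring. For the measured compounds named here, the one step that bears on it is the lengthening from compound 1 to compound 2, which was a 2.0-fold lower number from compound 1 to compound 2 (0.30 log units; within the scatter), within the scatter. Compound 3 cuts back part of that chain, so on this evidence the step is expected to be small and, if anything, toward a higher number: a 1.4-fold higher number from compound 2 to compound 3 (0.15 log units; within the scatter). Compound 3 is therefore estimated at 6500 nM, with a range of 3300 nM to 13000 nM in this assay.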

Compound 3, concentration for 50% growth inhibition: 3710 nM
Beside the measured number, compound 3's estimate is 1.8-fold (0.24 log units) above it; measured number inside the range.
By their numbers in this assay, from the lowest: compounds 3, 2 and 1 (each within the scatter of the next, the first and the last beyond it).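

In this assay the chain now has a third length on the shared core, and taking ethyl off the octyl chain gives a 1.2-fold lower number from compound 2 to compound 3 (0.10 log units; within the scatter) and so does not separate the two compounds. For the compounds shown here, the single change of methyl in place of hydrogen, five bonds along the chain from a nitrogen on an aromatic ring, gives a 2.5-fold lower number from compound 1 to compound 3 (0.39 log units; beyond the scatter) and is the first modest step at this position to stand beyond the scatter, although compound 2 stays within the scatter of both compound 1 and compound 3. No measurement at hand accounts for this step.

From the compounds shown here alone, whether a longer chain would keep these values or shift them remains open. So does the effect of a chain ending in an amine or a carboxylic acid at this position.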